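Carbamate chain homologation and half-life in buffer

This account rests on a few compounds, and the source may have more. Where it says the series, first, only, none or still open, it means among the compounds named here.

Compound 1 `CCCCCCCNC(=O)Oc1ccc(Cl)cc1C(=O)Nc1cccc(Cl)c1` and compound 2 `CCCCCCCCNC(=O)Oc1ccc(Cl)cc1C(=O)Nc1cccc(Cl)c1` share a core and differ by methyl in place of hydrogen on a saturated chain carbon, seven bonds along the chain from an amide-type nitrogen. In an ADME assay for metabolic stability, read by HPLC, at pH 7 (on this read-out higher numbers stand for a longer-lived compound and lower numbers for a shorter-lived compound), compound 1 gives 64 h and compound 2 gives 64 h, so no change at the digits printed from compound 1 to compound 2 (within the scatter). Compound 3 `CCNC(=O)Oc1ccc(Cl)cc1C(=O)Nc1ccc(Cl)cc1` is built on a core whose difference from compound 1 is not broken down here; in this assay compound 3 gives 64 h, level with compounds 1 and 2 at the digits read.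

Compound 4 `CCCNC(=O)Oc1ccc(Cl)cc1C(=O)Nc1ccc(Cl)cc1` has not been run. It differs from compound 3 by methyl in place of hydrogen on a saturated chain carbon, two bonds along the chain from an amide-type nitrogen. This is the same kind of change as that from compound 1 to compound 2, not the same change: there the entering methyl sits seven bonds along the chain from an amide-type nitrogen, here two bonds along the chain from an amide-type nitrogen. Among the measured compounds shown here, the one measured example, no change at the digits printed from compound 1 to compound 2 (within the scatter), is the only footing, and on it the step from compound 3 to compound 4 is expected to be no change at the digits printed from compound 3 to compound 4 (within the scatter). Compound 4 is therefore estimated at 64 h, within 32 h to 110 h, because compound 3 stands at 64 h and the earlier methyl step read no change at the digits printed from compound 1 to compound 2 (within the scatter).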

Compound 4, half-life: 64 h
Compound 4: middle estimate and measured number agree at the digits printed, within the range that was stated.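

In this assay, the new methyl step reads no change at the digits printed from compound 3 to compound 4 (within the scatter). Set beside the earlier step on the other core, the change carries across the two cores with no gap beyond the scatter: the same change on two cores in this assay, no change at the digits printed (within the scatter) from compound 1 to compound 2 and no change at the digits printed (within the scatter) from compound 3 to compound 4, 1.0-fold (0.00 log units) apart, within the scatter of two such steps This rests on only two steps, with the entering methyl seven bonds along the chain from an amide-type nitrogen in one and two bonds along the chain in the other, so it does not show that the same result would hold on a further core or at another place on the chain.

The compounds shown carry only unbranched saturated chains on the amide-type nitrogen, so they leave open how a branched chain, a cyclohexyl group, or a chain ending in an amine or a carboxylic acid would read in this assay. They also leave open whether any change at this nitrogen can move the half-life away from the level shared by these four compounds.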